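A few compounds are considered here, and "the series" means these few. Any claim that something is new, unique, unknown or untested is made for them only; others in the source may bear on it.

Measured compounds:
compound 1 `COc1ccc([C@@H]2CC(=O)c3c(O)cc(OCc4cn(Cc5cccc(Cl)c5)nn4)cc3O2)cc1O` gives 18200 nM
compound 2 `COc1ccc([C@@H]2CC(=O)c3c(O)cc(OCc4cn(Cc5ccccc5)nn4)cc3O2)cc1O` gives 11000 nM
compound 3 `COc1ccc([C@@H]2CC(=O)c3c(O)cc(OCc4cn(Cc5ccccc5C#N)nn4)cc3O2)cc1O` gives 14600 nM

In a functional assay on RAW264.7 cells (Mus musculus) for inhibition, read by Griess assay, with stated times of 2 h and 24 h (on this read-out lower numbers stand for stronger inhibition and higher numbers for weaker inhibition), compound 3 stands second highest of the three numbers; its nearest neighbour is compound 1 and its furthest is compound 2, and both gaps lie within the scatter. Compound 4 `COc1ccc([C@@H]2CC(=O)c3c(O)cc(OCc4cn(Cc5ccc(F)cc5)nn4)cc3O2)cc1O` differs from compound 3 in one place: 4-fluorophenyl in place of 2-cyanophenyl on a saturated chain carbon bound to an aromatic nitrogen. For the measured compounds named here, three measured steps bear on this change, since each swaps a substituent on the same phenyl ring. Removing the chloro gave a 1.7-fold lower number from compound 1 to compound 2 (0.22 log units; within the scatter), adding the cyano gave a 1.3-fold higher number from compound 2 to compound 3 (0.12 log units; within the scatter), and exchanging the two substituted phenyls gave a 1.2-fold lower number from compound 1 to compound 3 (0.10 log units; within the scatter). None of these moved the number beyond the scatter, so the substituent on this ring has so far made no detectable difference in this assay. The fluoro variant is therefore expected to behave likewise, and the expected step of a 1.1-fold lower number from compound 3 to compound 4 (0.03 log units; within the scatter) is none beyond the scatter. Compound 4 is expected to give about 13500 nM in this assay, with a likely range from 6500 nM to 28000 nM.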

Compound 4, half-maximal inhibitory concentration: 15100 nM
Estimate against measurement, compound 4: 1.1-fold (0.05 log units) below; the range from low to high includes it.
By their numbers in this assay, from the lowest: compounds 2, 3, 4 and 1 (each within the scatter of the next).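

In this assay the 4-fluorophenyl group behaves as the other rings on this saturated chain carbon do: the step is a 1.0-fold higher number from compound 3 to compound 4 (0.01 log units; within the scatter) and against the other two compounds it is a 1.4-fold higher number from compound 2 to compound 4 (0.14 log units; within the scatter) and a 1.2-fold lower number from compound 1 to compound 4 (0.08 log units; within the scatter). Fluoro thus joins chloro and cyano, and the plain phenyl, 3-chlorophenyl, 2-cyanophenyl and 4-fluorophenyl compounds cannot be told apart here, so this flat picture now holds across all four compounds with none going against it. Nothing available explains this result.

All the groups shown are small substituents on a phenyl ring, so it remains open whether an amine or a carboxylic acid on that ring would move the number beyond the scatter. As far as these compounds go, it is equally open whether a longer chain in place of the single saturated carbon, or a plain alkyl chain in place of the phenyl, would do so.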